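The source may hold more compounds than are shown below. What is called first, only, known or untested is meant among the compounds shown, and "the series" means these compounds.

Among the measured compounds shown here, in a functional assay on the whole organism with Rattus norvegicus as the target (on this read-out lower numbers stand for an effect already at smaller amounts and higher numbers for an effect only at larger amounts of compound), compound 2 (`C=C/C(C)=C/[C@](C)(O)C/C=C/[C@H]1[C@H](O)CC(=O)[C@@H]1CC/C=C\CCC(=O)OC`) gives 1.03 mg/kg as the only exact number so far. In this assay compound 1 (`COC(=O)CC/C=C\CC[C@H]1C(=O)C[C@@H](O)[C@@H]1/C=C/C[C@@](C)(O)/C=C/C(C)=C(C)C`) is reported as > 3.16 mg/kg and that figure is a limit. For the measured compounds named here, the one measured step is an at least 3.0-fold lower number from compound 1 to compound 2 (0.48 log units; beyond the scatter) and it lies at the same place that changes next: on a saturated chain carbon bound to an oxygen on a saturated carbon and two saturated chain carbons. Compound 3 (`C=C(C)/C=C/[C@](C)(O)C/C=C/[C@H]1[C@H](O)CC(=O)[C@@H]1CC/C=C\CCC(=O)OC`) has the same atoms as compound 2, joined differently (3-methylbuta-1,3-dien-1-yl in place of 2-methylbuta-1,3-dien-1-yl on a saturated chain carbon bound to an oxygen on a saturated carbon and two saturated chain carbons), with 3-methylbuta-1,3-dien-1-yl in place of 2-methylbuta-1,3-dien-1-yl. The measured step removed 3,4-dimethylpenta-1,3-dien-1-yl, a group that takes no part in this new exchange, so it is only a loose guide here. In this assay no shift beyond the scatter is therefore expected, with compound 2 at 1.03 mg/kg as the starting point. The estimated change is a 1.4-fold higher number from compound 2 to compound 3 (0.13 log units; within the scatter) and no more. For compound 3 the expected value is 1.4 mg/kg with an estimated range from 0.5 mg/kg to 4.5 mg/kg for a real measurement.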

Compound 3, dose for half-maximal effect: 0.42 mg/kg
For compound 3 the middle estimate is 3.3-fold (0.52 log units) above the measured one, outside the stated range (below it).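

In this assay, 2-methylbuta-1,3-dien-1-yl and 3-methylbuta-1,3-dien-1-yl have the same atoms and the same number of double bonds, yet exchanging one for the other on a saturated chain carbon bound to an oxygen on a saturated carbon and two saturated chain carbons gives a 2.5-fold lower number from compound 2 to compound 3 (0.39 log units; beyond the scatter), so at this place the way the atoms are joined matters, not only which atoms are present. The same series also allows a direct reading against the group of compound 1, where 1-methylethenyl in place of 1,2-dimethylprop-1-en-1-yl on a double-bonded chain carbon bound to a double-bonded chain carbon gives an at least 7.5-fold lower number from compound 1 to compound 3 (0.87 log units; beyond the scatter). That step can be read only as a minimum, because the value of compound 1 is a limit and not a number: the limit of > 3.16 mg/kg in this assay, at which 1 of the 3 values shown sits.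

The compounds shown leave open what a plain buta-1,3-dien-1-yl with no methyl, or a longer chain such as hexa-1,3-dien-1-yl, would give at this place. They also leave open whether the difference between compound 2 and compound 3 would carry over if a carboxylic acid replaced the methyl ester.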